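From compound 3 to compound 4: a pyridin-2-yl exchange

The source may hold more compounds than are shown below. What is called first, only, known or untested is meant among the compounds shown, and "the series" means these compounds.

Of the compounds shown here, three sharing one core have been read in a functional assay on MCF7 cells (Homo sapiens) for cytotoxicity, read by MTT assay, with a stated time of 48 h; on this read-out higher numbers stand for weaker inhibition and lower numbers for stronger inhibition. Compound 1 `Cc1ccccc1-c1nnc(SCCn2c([N+](=O)[O-])cnc2C)o1` gives 15800 nM, compound 2 `Cc1ccc(-c2nnc(SCCn3c([N+](=O)[O-])cnc3C)o2)cc1` gives 15500 nM and compound 3 `Cc1ncc([N+](=O)[O-])n1CCSc1nnc(-c2ccc(F)cc2)o1` gives 8100 nM. Compound 3 stands within the scatter of both others, as shown by a 2.0-fold lower number from compound 1 to compound 3 (0.29 log units; within the scatter) and a 1.9-fold lower number from compound 2 to compound 3 (0.28 log units; within the scatter). The remaining step, a 1.0-fold lower number from compound 1 to compound 2 (0.01 log units; within the scatter), is also within the scatter, so the three values form one group with no readable order.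

Compound 4 `Cc1ncc([N+](=O)[O-])n1CCSc1nnc(-c2ccccn2)o1` has not yet been measured. Its difference from compound 3 is pyridin-2-yl in place of 4-fluorophenyl on an aromatic carbon of a five-membered aromatic ring with 2 nitrogen and 1 oxygen. For the measured compounds named here, no measured compound carries a ring with a hetero atom at this place, so the data offer no direct precedent. The nearest guide is the pair of steps into compound 3 given above, both of which exchange the group on that same carbon and stay within the scatter. The expected 1.4-fold higher number from compound 3 to compound 4 (0.13 log units; within the scatter) in this assay is therefore no change beyond the scatter, with no firm direction. Compound 4 is estimated at 11000 nM, with an expected range of 5000 nM to 25000 nM.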

Compound 4, half-maximal inhibitory concentration: 39100 nM
Compound 4: the middle estimate sits 3.6-fold (0.55 log units) below what was measured, outside the stated range (above it).
By their numbers in this assay, from the lowest: compounds 3, 2 and 1 (each within the scatter of the next); then compound 4.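

For the compounds shown here, this position on the shared core proved more responsive than the earlier compounds suggested: in this assay, the phenyl groups carrying methyl or fluoro stayed within the scatter of one another, whereas pyridin-2-yl gives a 4.8-fold higher number from compound 3 to compound 4 (0.68 log units; beyond the scatter). The separation also holds against the two methylphenyl compounds, with a 2.5-fold higher number from compound 2 to compound 4 (0.40 log units; beyond the scatter) and a 2.5-fold higher number from compound 1 to compound 4 (0.39 log units; beyond the scatter), so compound 4 is the weakest of the four and the only one that stands apart from the rest. The exchange places a ring nitrogen and a hydrogen-bond acceptor on the aromatic carbon next to the ring nitrogen and the ring oxygen, but nothing available explains the higher number or shows which of these differences matters.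

The compounds shown leave open whether the ring nitrogen itself or the absence of a substituent on the six-membered ring goes with the weaker result, a question that unsubstituted phenyl and a fluorinated pyridine ring at this carbon could separate. Also open, on these data alone, is how a five-membered ring such as thiophene or furan, or an amine on the phenyl ring, would read here.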